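The source may hold more compounds than are shown below. What is called first, only, known or untested is meant among the compounds shown, and "the series" means these compounds.

Of the compounds shown here, three built on a shared core have been tested so far: compound 1 `COc1nc(Cl)nc2c1ncn2[C@@H]1O[C@H](CO)[C@@H](O)[C@@]1(C)O`, compound 2 `C[C@@]1(O)[C@H](O)[C@@H](CO)O[C@H]1n1cnc2c(N)nc(N=[N+]=[N-])nc21` and compound 3 `C[C@@]1(OC(=O)c2ccccc2)[C@H](OC(=O)c2ccccc2)[C@@H](COC(=O)c2ccccc2)O[C@H]1n1cnc2c(N)nc(NO)nc21`. The test used is an ADME assay on PBMC cells (Homo sapiens) for cytotoxicity, with a stated time of 5 days; on this read-out higher numbers stand for lower toxicity in this test and lower numbers for higher toxicity in this test. Compound 1 gives > 100000 nM, which is a limit of the assay and not a number. Compound 2 gives > 100000 nM, again a limit. Compound 3 gives > 100000 nM, also a limit. Compound 3 therefore stands with the other two at the limit of > 100000 nM in this assay, at which 3 of the 3 values shown sit, so no true number is known for any of them.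

Compound 4 `C[C@@]1(OC(=O)c2ccccc2)[C@H](OC(=O)c2ccccc2)[C@@H](COC(=O)c2ccccc2)O[C@H]1n1cnc2c(Cl)nc(NO)nc21` is compound 3 with a single change: chloro in place of amino on an aromatic carbon, meta to a hydroxyamino group (chloro in place of amino on an aromatic carbon). Among the measured compounds shown here, no measured pair shows what such a swap does, so any forecast here is uncertain. A chloro group is not new to this set, since compound 1 also carries one on the shared core, though in another place. The expectation is therefore a modest step towards lower numbers, or possibly none that the assay can show. The expected change is an at least 1.4-fold lower number from compound 3 to compound 4 (0.15 log units; that floor lies within the scatter), which is only an estimate. Compound 4 is expected at 70000 nM, within an estimated range of 20000 nM to 100000 nM.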

Compound 4, half-maximal cytotoxic concentration: 43000 nM
Estimate against measurement, compound 4: 1.6-fold (0.21 log units) above, within the range that was stated.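

In this assay, chloro in place of amino on an aromatic carbon, meta to a hydroxyamino group, gives an at least 2.3-fold lower number from compound 3 to compound 4 (0.36 log units; beyond the scatter), so this position is one where a single swap can move the read-out towards higher toxicity in this test. Among the compounds shown here, compound 4 gives 43000 nM, which is the first true number in the set and not a limit of the assay, so the shared core now has a measured value to which later changes can be compared. The size of the step remains a floor and not an exact figure because compound 3 itself sits at a limit, not at a number: the limit of > 100000 nM in this assay, at which 3 of the 4 values shown sit.

For the compounds shown here, the single pair cannot separate the effect of losing amino from the effect of gaining chloro, and a fluoro or bromo group, or a dimethylamino group, at this position would help to tell the two apart. From the compounds shown here alone, it also stays open whether the same swap would lower the number on a compound with free hydroxyl groups on the sugar-like ring, or without the hydroxyamino group that compound 3 and compound 4 share.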